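Aryl Swap on a Shared Core: Expectation for Compound 3

The source may report more compounds than this note shows. Statements on the series, on what has been measured and on what is new or still open speak of the compounds shown alone.

Compound 1 `CCC1=C(O)c2c(oc(-c3ccc(Br)cc3)cc2=O)C(CC)(CC)C1=O` carries the higher of the two numbers recorded in a functional assay on KBVIN cells (Homo sapiens) for antiproliferative activity, read by sulforhodamine B assay, with a stated time of 3 days (on this read-out higher numbers stand for an effect only at larger amounts of compound and lower numbers for an effect already at smaller amounts), giving 15.7 uM; compound 2 `CCC1=C(O)c2c(oc(-c3cccc(OC(F)(F)F)c3)cc2=O)C(CC)(CC)C1=O` gives 9.95 uM, and the two values lie within the scatter of each other. Compound 3 `CCC1=C(O)c2c(oc(-c3ccc(OC)c(C)c3)cc2=O)C(CC)(CC)C1=O` differs from compound 1 by 4-methoxy-3-methylphenyl in place of 4-bromophenyl on an aromatic carbon. Going by the values given here, no measured pair shows what this kind of change does, so the two recorded values are the only footing. Compound 3 is expected to give about 12 uM, within a range of 4 uM to 35 uM. The step of a 1.3-fold lower number from compound 1 to compound 3 (0.12 log units; within the scatter) is accordingly expected to remain within the scatter, with no clear direction.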

Compound 3, concentration for half-maximal effect: 0.1 uM
Compound 3: middle estimate off by 120-fold (2.08 log units), on the high side, outside the stated range (below it).
By their numbers in this assay, from the lowest: compound 3; then compounds 2 and 1 (each within the scatter of the next).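

In this assay the aryl group on the aromatic carbon next to the ring oxygen proves decisive for the shared core: 4-methoxy-3-methylphenyl in place of 4-bromophenyl brings a 160-fold lower number from compound 1 to compound 3 (2.20 log units; beyond the scatter) as a large change. This single exchange therefore moves the number far beyond the scatter, so this position responds strongly to the choice of aryl group. Nothing in the available data explains the step.

The compounds shown leave open whether the methoxy group or the methyl group alone would produce this step. They also leave open whether an amine or an ethoxy group in place of the methoxy group would preserve it.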